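Compound 4 built from compound 3: what to expect

The compounds below may be only part of what the source reports. "The series", "measured", "known", "first", "only" and "open" are said of these compounds alone.

Of the compounds shown here, three sharing one core have been measured in a functional assay on UACC-62 cells (Homo sapiens) for cytotoxicity, read by sulforhodamine B assay; on this read-out lower numbers stand for higher toxicity in this test and higher numbers for lower toxicity in this test. Compound 1 `CC1=CC[C@@H]([C@@](C)(O)CCCC(C)(C)NC(=S)N/N=C\c2ccccc2)CC1` gives 48400 nM, compound 2 `CC1=CC[C@@H]([C@@](C)(O)CCCC(C)(C)NC(=S)N/N=C\c2ccc(C)cc2)CC1` gives 52300 nM, and compound 3 `CC1=CC[C@@H]([C@@](C)(O)CCCC(C)(C)NC(=S)N/N=C\c2ccc(Cl)cc2)CC1` gives 40600 nM. Compound 3 carries the lowest of the three numbers, yet the separations are small: a 1.2-fold lower number from compound 1 to compound 3 (0.08 log units; within the scatter) and a 1.3-fold lower number from compound 2 to compound 3 (0.11 log units; within the scatter), both within the scatter, as is a 1.1-fold higher number from compound 1 to compound 2 (0.03 log units; within the scatter).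

Compound 4 `CC1=CC[C@@H]([C@@](C)(O)CCCC(C)(C)NC(=S)N/N=C(/C)c2ccccc2)CC1` differs from compound 3 by a group of 9 heavy atoms (8 carbon, 1 nitrogen; one six-membered aromatic ring of carbon only) in place of a group of 9 heavy atoms (7 carbon, 1 nitrogen, 1 chlorine; one six-membered aromatic ring of carbon only), on an amide-type nitrogen. Within the data shown here, no measured step alters this place in the same way; the steps among compounds 1, 2 and 3 only exchange substituents on the aromatic ring, and every one of them stays within the scatter. With such flat ground behind it, the account expects no step beyond the scatter in this assay from compound 3 to compound 4. The estimate for compound 4 in this assay is 45000 nM, with a range from 20000 nM to 100000 nM. The expected step is a 1.1-fold higher number from compound 3 to compound 4 (0.04 log units; within the scatter).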

Compound 4, concentration lethal to 50% of the cells: > 100000 nM
Compound 4 gave a limit, no number (the forecaster's own chance of this, stated with the estimate: 5%); at least 2.2-fold (0.34 log units) between middle value and limit.
By their numbers in this assay, from the lowest: compounds 3, 1 and 2 (each within the scatter of the next). At a limit, above all of these: compound 4.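

Compound 4 gives only a limit in this assay: the limit of > 100000 nM in this assay, at which 1 of the 4 values shown sits.

The substituent exchanges on the aromatic ring among compounds 1, 2 and 3 all stayed within the scatter, but changing the group on the amide-type nitrogen gives an at least 2.4-fold higher number from compound 3 to compound 4 (0.39 log units; beyond the scatter) and an at least 2.0-fold higher number from compound 1 to compound 4 (0.31 log units; beyond the scatter). The third step, an at least 1.9-fold higher number from compound 2 to compound 4 (0.28 log units; that floor lies within the scatter), has a floor within the scatter and so does not establish a separation by itself. This place is thus the first in the series shown to move the read-out beyond the scatter, in the direction of lower toxicity in this test.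

The limit leaves the true size of these steps open. Also open, on these data alone, is whether an ethyl group or a longer chain in the same place would behave as the group in compound 4 does.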